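A Bromo Step on a Weak Compound

The compounds below may be only part of what the source reports. "The series", "measured", "known", "first", "only" and "open" are said of these compounds alone.

Measured in a functional assay on MCF7 cells (Homo sapiens) for antiproliferative activity, read by MTT assay, with a stated time of 48 h (on this read-out lower numbers stand for stronger inhibition and higher numbers for weaker inhibition), so far are three compounds:
- compound 1 `O=C(/C=C/c1ccc2c(c1)OCCO2)NS(=O)(=O)c1ccccc1` gives 2.16 ug/mL
- compound 2 `O=C(/C=C/c1ccc2c(c1)OCCO2)NS(=O)(=O)c1ccc(F)cc1` gives 52.1 ug/mL
- compound 3 `O=C(/C=C/c1ccc2c(c1)OCCCO2)NS(=O)(=O)c1ccccc1` gives 53.9 ug/mL

Compound 3 stands level with compound 2 on these numbers, since their values lie within the usual scatter of each other. Compound 1 reads far lower, so it inhibits much more strongly than either.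

The next compound, compound 4 `O=C(/C=C/c1ccc2c(c1)OCCCO2)NS(=O)(=O)c1ccc(Br)cc1`, keeps the core of compound 3 and has bromo in place of hydrogen on an aromatic carbon, para to a large group. The change from phenyl to 4-bromophenyl is counted as bromo in place of hydrogen on an aromatic carbon and has not yet been tested.

Among the measured compounds shown here, only one measured step is similar: fluoro in place of hydrogen, which gave a 24-fold higher number from compound 1 to compound 2 (1.38 log units; beyond the scatter) and counts as large. It is only a rough guide, as it involves a different halogen and starts from the core of compound 1. For the measured compounds named here, no measured step starts from the core of compound 3, which already reads 53.9 ug/mL without any halogen. The direction is therefore expected to hold, but not the size.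

In this assay the expected change is a 1.3-fold higher number from compound 3 to compound 4 (0.11 log units; within the scatter) and is a small move towards weaker inhibition. For compound 4 the estimated value is 70 ug/mL with an expected range from 18 ug/mL to 250 ug/mL.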

Compound 4, half-maximal inhibitory concentration: > 100 ug/mL
Compound 4: only a limit was reported (the forecaster's own chance of this, stated with the estimate: 15%); middle value at least 1.4-fold (0.15 log units) from the limit.
By their numbers in this assay, from the lowest: compound 1; then compounds 2 and 3 (each within the scatter of the next). At a limit, above all of these: compound 4.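

Compound 4 reads > 100 ug/mL in this assay, which is a limit of the assay and not a number, and it is the only reading of this kind among the compounds shown: the limit of > 100 ug/mL in this assay, at which 1 of the 4 values shown sits.

Going by these compounds, the change from phenyl to 4-bromophenyl on the core of compound 3 therefore comes to an at least 1.8-fold higher number from compound 3 to compound 4 (0.26 log units; that floor lies within the scatter), so this halogen brings no stronger inhibition into view on a compound that was already weak, while the size of the change stays unknown and could be larger than this floor. Among the compounds shown here, until now the only halogen step was fluoro on the core of compound 1, a 24-fold higher number from compound 1 to compound 2 (1.38 log units; beyond the scatter), and this second step, on a different core and with a different halogen, also shows no lower number, although only the fluoro step is beyond the scatter.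

On these data alone, it remains open whether a group that is not a halogen, such as a methoxy group or an amine, would give a lower number at this same place on the core of compound 3. As far as these compounds go, it also remains open how bromo would read on the core of compound 1, where the unsubstituted compound 1 gives 2.16 ug/mL.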